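Working notes: amide partner change and tolerated concentration

This account rests on a few compounds, and the source may have more. Where it says the series, first, only, none or still open, it means among the compounds named here.

Measured so far:
Compound 1, `CC(C)n1ncc2c(C(=O)Nc3ccccn3)cc(-c3ccsc3)nc21`, gives 25000 nM in an ADME assay on LLC-MK2 cells (Macaca mulatta) for cytotoxicity, read by spectrophotometry and crystal violet staining, with a stated time of 4 days; a lower number here means that less compound is tolerated, a higher number that more compound is tolerated.
Compound 2, `CC(C)n1ncc2c(C(=O)Nc3ccccn3)cc(-c3ccccc3)nc21`, gives 12500 nM in this assay.
Compound 3, `CC(C)n1ncc2c(C(=O)N3CCc4cccnc43)cc(-c3cccs3)nc21`, gives 50000 nM in this assay.

Compound 3 has the highest of the three numbers in this assay, but its gap to compound 1 is within the scatter, so the two are not separated; only its gap to compound 2 is beyond the scatter. Going by the values given here, the one single-site step measured so far, a 2.0-fold lower number from compound 1 to compound 2 (0.30 log units; within the scatter), concerns the group on an aromatic carbon, not the amide, and is itself within the scatter.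

Compound 4, `CC(C)n1ncc2c(C(=O)Nc3ccccc3F)cc(-c3cccs3)nc21`, keeps the thiophen-2-yl of compound 3 and changes the amide partner: a group of 8 heavy atoms (6 carbon, 1 nitrogen, 1 fluorine; one six-membered aromatic ring of carbon only) in place of a group of 9 heavy atoms (7 carbon, 2 nitrogen; one five-membered non-aromatic ring with 1 hetero atom, one six-membered aromatic ring with 1 hetero atom), on a carbonyl carbon, on a carbonyl carbon. Among the compounds with values here, no measured step touches this position, so nothing in the data points to a shift in either direction. Across all three compounds the numbers sit within a narrow band, and compound 4 is expected to stay in it, with a 1.4-fold lower number from compound 3 to compound 4 (0.15 log units; within the scatter) as the estimated step. In this assay compound 4 is therefore estimated at 35000 nM, with a range from 12500 nM to 100000 nM.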

Compound 4, half-maximal cytotoxic concentration: 50000 nM
Beside the measured number, compound 4's estimate is 1.4-fold (0.15 log units) below it; the measured number falls inside the stated range.
By their numbers in this assay, from the lowest: compounds 2, 1, 3 and 4 (each within the scatter of the next, the first and the last beyond it).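

In this assay, going by these compounds alone, the exchange of the group of 9 heavy atoms for (2-fluorophenyl)amino on the carbonyl carbon gives no change at the digits printed from compound 3 to compound 4 (within the scatter) and is the first measured step at this position. What is counted changes considerably, with the five-membered non-aromatic ring gone and a group with 0 hydrogen-bond donors and 1 hydrogen-bond acceptor replaced by one with 1 hydrogen-bond donor and 0 hydrogen-bond acceptors, yet the read-out does not separate the two compounds. No measurement at hand bears on this result.

With a single step at this position and thiophen-2-yl kept throughout it, the compounds shown do not tell whether the same would hold for an amide partner carrying an amine or a carboxylic acid, or for a longer chain on the carbonyl carbon. Also open, as far as these compounds go, is whether this amide change reads the same with phenyl or thiophen-3-yl on the aromatic carbon; compound 1 and compound 2 differ from compound 3 and compound 4 in more than one place and give no single-site comparison.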